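Thioether series: a larger group on the five-membered ring

The source may report more compounds than this note shows. Statements on the series, on what has been measured and on what is new or still open speak of the compounds shown alone.

Measured so far:
compound 1 `c1ccc(Sc2ncnc3[nH]cnc23)cc1`, 0% in an assay on isolated protein for inhibition of Ca2+/calmodulin-dependent protein kinase II (CaM kinase II) (Rattus norvegicus), tested at 30 uM; a lower number here means less inhibition, a higher number more inhibition at the concentration tested (going by the name of the read-out)
compound 2 `Cn1cnc2c(Sc3ccccc3)ncnc21`, 8%
compound 3 `Cn1cnc2c(Sc3ccc(F)cc3)ncnc21`, 5%

Compound 2 gives the highest of the three numbers, but the steps of a number 8 percentage points higher from compound 1 to compound 2 (within the scatter) and a number 3 percentage points lower from compound 2 to compound 3 (within the scatter) both lie within the scatter, so no order among the three is claimed.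

Compound 4 `CSc1ccc(-c2nc3c(Sc4ccccc4)ncnc3n2C)cc1` differs from compound 2 by 4-(methylsulfanyl)phenyl in place of hydrogen on an aromatic carbon. Neither measured step concerns a change of this kind, and both were within the scatter. Nothing measured therefore supports a step beyond the scatter in this assay, though the entering group is far larger than anything varied so far, so the range is wide. Compound 4 is expected to give 12% (range 0% to 35%), an expected step of a number 4 percentage points higher from compound 2 to compound 4 (within the scatter).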

Compound 4, a percentage reported as inhibition, at one concentration (the size of the read-out at that concentration, not a potency): 0%
For compound 4 the middle estimate is 12 percentage points above the measured one, within the range that was stated.
By their numbers in this assay, from the lowest: compounds 1, 4, 3 and 2 (each within the scatter of the next).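

On the aromatic carbon between two ring nitrogen atoms, 4-(methylsulfanyl)phenyl in place of hydrogen adds far more than any earlier change, yet a number 8 percentage points lower from compound 2 to compound 4 (within the scatter) in this assay and so does not separate the two compounds. Even a group of this size at this position thus gives no step beyond the scatter. Nothing available bears on why this is so.

Still open, as far as these compounds go, is whether an amine or a carboxylic acid on this same carbon would give a step beyond the scatter. Also open, from the compounds shown here alone, is whether any group at this position gives clear inhibition at the concentration tested.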